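A few compounds are considered here, and "the series" means these few. Any claim that something is new, unique, unknown or untested is made for them only; others in the source may bear on it.

Working notes on the series in an in vitro functional assay on 1321-N1 cells for agonist activity at Free fatty acid receptor 1 (Homo sapiens), read by fluorescence; on this read-out higher numbers stand for an effect only at larger amounts of compound and lower numbers for an effect already at smaller amounts. Compound 1 `O=C(O)CCc1ccc(C#Cc2ccccc2)cc1` gives 95.5 nM; 96 nM (2 entries), with the repeat agreeing as shown by the several entries of compound 1 in this assay, 95.5 nM; 96 nM (2 entries). Compound 2 `Cc1cccc(C#Cc2ccc(CCC(=O)O)cc2)c1` gives 43.7 nM, the only number shown for it; a further entry for compound 2 carries no single number. The two values of compound 1 and compound 2 are the whole of what is known here.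

Compound 3 `O=C(O)CCc1ccc(C#Cc2cccc(C(F)(F)F)c2)cc1` differs from compound 2 by trifluoromethyl in place of methyl on an aromatic carbon. Within the data shown here, no step between measured compounds of this kind is recorded, so nothing measured anchors it. For compound 3 the step from compound 2 is expected to be a 1.1-fold lower number from compound 2 to compound 3 (0.04 log units; within the scatter), within the scatter in either direction. The estimate for compound 3 is 40 nM, with a range from 12 nM to 150 nM.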

Compound 3, half-maximal effective concentration: 89.1 nM
Compound 3: middle estimate off by 2.2-fold (0.35 log units), on the low side; the range from low to high includes it.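

In this assay, this position does not treat the two groups alike: trifluoromethyl in place of methyl gives a 2.0-fold higher number from compound 2 to compound 3 (0.31 log units; beyond the scatter), a modest step and the first one measured here. Compound 3 at 89.1 nM and compound 1 at 95.5 nM; 96 nM (2 entries) have printed values close together, so only the methyl of compound 2 stands apart from them. Repeat readings at this level agree closely: the several entries of compound 1 in this assay, 95.5 nM; 96 nM (2 entries)

The compounds shown leave open how a methoxy, a chlorine or a nitrile would read at this position. They also leave open whether the same exchange gives a similar step elsewhere on the ring.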